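Phenyl Substitution Repeated on a Second Benzamide Core

The source may hold more compounds than are shown below. What is called first, only, known or untested is meant among the compounds shown, and "the series" means these compounds.

Compound 3 `CN(C)c1ccc(C(=O)N(CC(=O)NCc2ccccc2)Cc2ccc(C(=O)Nc3ccccc3N)cc2)cc1` is the simplest of the three measured compounds; in a functional assay on CAL-27 cells (Homo sapiens) for cytotoxicity, read by MTT assay, with a stated time of 72 h (on this read-out higher numbers stand for weaker inhibition and lower numbers for stronger inhibition), compound 3 gives 1600 nM. Compound 1 `CN(C)c1ccc(C(=O)N(CC(=O)NCc2ccccc2)Cc2ccc(C(=O)Nc3cc(-c4ccccc4)ccc3N)cc2)cc1` differs from it by a single change, (phenyl in place of hydrogen on an aromatic carbon), and in this assay compound 1 gives 11100 nM, which amounts to a 6.9-fold higher number from compound 3 to compound 1 (0.84 log units; beyond the scatter). Compound 2 `Cc1cc(C)cc(C(=O)N(CCCCCC(=O)Nc2ccccc2N)CC(=O)NCc2ccccc2)c1` is built on another core, and the difference between the two cores is not broken down here; in this assay compound 2 gives 13700 nM, close to compound 1 and well apart from compound 3.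

Compound 4 `Cc1cc(C)cc(C(=O)N(CCCCCC(=O)Nc2cc(-c3ccccc3)ccc2N)CC(=O)NCc2ccccc2)c1` has not yet been measured. It stands to compound 2 as compound 1 stands to compound 3: phenyl in place of hydrogen on an aromatic carbon, the same change at the same kind of place. Going by the values given here, only one measured example of this change exists, so the expectation rests on that single step. Because a 6.9-fold higher number from compound 3 to compound 1 (0.84 log units; beyond the scatter) was a clear weakening, the step from compound 2 to compound 4 is expected to be of similar size, estimated at a 5.8-fold higher number from compound 2 to compound 4 (0.77 log units; beyond the scatter). Compound 4 is therefore expected to give about 80000 nM in this assay, estimated between 25000 nM and 200000 nM.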

Compound 4, half-maximal inhibitory concentration: 18900 nM
Compound 4: the middle estimate sits 4.2-fold (0.63 log units) above what was measured; the measured number lies below the stated range.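

In this assay, phenyl in place of hydrogen on an aromatic carbon gives a 1.4-fold higher number from compound 2 to compound 4 (0.14 log units; within the scatter), so on this core the change has no effect that can be told from the scatter. Set beside the earlier step, the same change does not carry over in size from one core to the other: the same change on two cores in this assay, a 6.9-fold higher number (0.84 log units; beyond the scatter) from compound 3 to compound 1 and a 1.4-fold higher number (0.14 log units; within the scatter) from compound 2 to compound 4, 5.0-fold (0.70 log units) apart, beyond the scatter of two such steps. Why the two steps part is not shown, and with only one pair on each core, no rule for any further core can be drawn.

The compounds shown leave open whether a smaller group at the same place, such as methyl or fluorine, or a phenyl carrying an amine, would follow the step seen on one core or on the other. They also leave open how the phenyl change would behave on a version of the second core with a longer chain.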